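Cytotoxicity limits on the way to compound 3

A few compounds are considered here, and "the series" means these few. Any claim that something is new, unique, unknown or untested is made for them only; others in the source may bear on it.

In a functional assay on RD cells (Homo sapiens) for inhibition, read by luminescence and ATP content, with a stated time of 72 h (a higher number here means that more compound is tolerated, a lower number that less compound is tolerated), compound 1 (`CCc1ccc(-c2ccc3ncc(-c4noc(CC)n4)cc3c2)cc1`) gives > 22200 nM, which is a limit and not a number. Compound 2 (`CCc1nc(-c2cnc3ccc(-c4ccc(O)cc4)cc3c2)no1`) gives > 2500 nM, which is also a limit, so compound 2 stands on a limit alone. Going by the values given here, the only measured step is a step that the two limits leave unreadable from compound 1 to compound 2, with hydroxy in place of ethyl on an aromatic carbon, and it offers no size to carry forward.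

Compound 3 (`CCc1nc(-c2cnc3ccc(-c4ccc(N)c(Cl)c4)cc3c2)no1`) has 4-amino-3-chlorophenyl in place of 4-hydroxyphenyl on an aromatic carbon. Among the compounds with values here, no measured step sets a size or direction for this change in this assay. The step expected is a step that the limit leaves unreadable from compound 2 to compound 3, an estimate with no measured size behind it. For compound 3 the estimated half-maximal cytotoxic concentration is 8000 nM, with an expected range of 2500 nM to 25000 nM.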

Compound 3, half-maximal cytotoxic concentration: > 7400 nM
Compound 3 gave a limit, no number; the forecaster's own chance of this, stated with the estimate: 60%; the middle value lies beyond the limit too.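

Going by these compounds alone, compound 1, compound 2 and compound 3 all stand on limits in this assay, and no step among them can be read. The compounds shown leave open where the half-maximal cytotoxic concentration of each actually lies, and whether either change on the aromatic carbon shifts it at all.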